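The compounds below may be only part of what the source reports. "The series", "measured", "known", "first", "only" and "open" are said of these compounds alone.

Compound 1 `COc1ccc(S(=O)(=O)N(Cc2cc(F)cc(F)c2)[C@H](C)C(=O)NO)cc1` gives 140 nM in an assay on isolated protein for inhibition of bone morphogenetic protein 1 (Homo sapiens); on this read-out higher numbers stand for weaker inhibition and lower numbers for stronger inhibition.
Compound 2 `COc1ccc(S(=O)(=O)N(Cc2cc(C(F)(F)F)cc(C(F)(F)F)c2)[C@H](C)C(=O)NO)cc1` gives 220 nM in this assay.
Compound 3 `COc1ccc(S(=O)(=O)N(CCn2cccc2)[C@H](C)C(=O)NO)cc1` gives 170 nM in this assay.

Compound 3 has the second highest of the three numbers, but its gaps to compound 1 and to compound 2 are both within the scatter, so the three compounds cannot be told apart on these data. The three share a core and differ only in the group on a saturated chain carbon bound to a sulfonamide nitrogen.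

Compound 4 `COc1ccc(S(=O)(=O)N(Cc2cc(C)on2)[C@H](C)C(=O)NO)cc1` has not yet been measured. It differs from compound 3 at that same position: 5-methyl-1,2-oxazol-3-yl in place of (1H-pyrrol-1-yl)methyl on a saturated chain carbon bound to a sulfonamide nitrogen.

Among the compounds with values here, one measured step bears on this change, since it alters the same group at the same place: a 1.2-fold higher number from compound 1 to compound 3 (0.08 log units; within the scatter). Compound 1 and compound 2 also differ only at this position, and their two values lie within the scatter of each other. Within this small set, exchanging the group at this position has not shifted the number beyond the scatter. The same outcome is expected here, with a 1.1-fold higher number from compound 3 to compound 4 (0.02 log units; within the scatter) as the expected step. For compound 4 the expected value in this assay is 180 nM, with a range from 80 nM to 400 nM.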

Compound 4, half-maximal inhibitory concentration: 230 nM
Estimate against measurement, compound 4: 1.3-fold (0.11 log units) below, within the range that was stated.
By their numbers in this assay, from the lowest: compounds 1, 3, 2 and 4 (each within the scatter of the next).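

Within the data shown here, the isoxazole result extends what the earlier compounds showed. In this assay, 5-methyl-1,2-oxazol-3-yl replaces (1H-pyrrol-1-yl)methyl with a 1.4-fold higher number from compound 3 to compound 4 (0.13 log units; within the scatter), and it replaces 3,5-difluorophenyl with a 1.6-fold higher number from compound 1 to compound 4 (0.22 log units; within the scatter), so neither exchange moves the number beyond the scatter. This adds a ring with two hetero atoms, a further hydrogen-bond acceptor by count, and a different link to the sulfonamide nitrogen, since the same difference, cut one bond further out, reads 2-(1H-pyrrol-1-yl)ethyl to (5-methyl-1,2-oxazol-3-yl)methyl, and all of these changes together leave the reading within the scatter of compound 3. No measurement available here accounts for how closely these values agree.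

Going by these compounds, all four groups at this position contain an aromatic ring, so it remains open how the number would respond to a group without one, such as an amine, a carboxylic acid or a plain longer alkyl chain. It also remains open what the methyl group on the ring of compound 4 contributes, since the same ring without that methyl is not among these compounds.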